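Series notes: amide substituent change from compound 3 to compound 4

This account rests on a few compounds, and the source may have more. Where it says the series, first, only, none or still open, it means among the compounds named here.

Three compounds of this series have numbers in a physicochemical assay for solubility, in phosphate buffer, measured as kinetic solubility, with a stated time of 1 h, at pH 7.4; on this read-out lower numbers stand for lower solubility and higher numbers for higher solubility. Compound 1 `COc1ccc2nc(C(F)(F)F)cc(OCC(=O)Nc3cc(C)cc(C)c3)c2c1` gives 15000 nM in this assay. Compound 2 `COc1ccc2nc(C)cc(OCc3ccc4ccccc4n3)c2c1` gives 21000 nM in this assay. Compound 3 `COc1ccc2nc(C)cc(OCC(=O)NCc3cc(C)cc(C)c3)c2c1` gives 92000 nM in this assay, the highest of the three numbers; its gap to compound 2 and its gap to compound 1 both lie beyond the scatter.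

The next compound, compound 4 `COc1ccc2nc(C)cc(OCC(=O)Nc3cc(C)c(F)c(C)c3)c2c1`, has not yet been measured in this assay. The change from compound 3 to compound 4 is 4-fluoro-3,5-dimethylphenyl in place of 3,5-dimethylbenzyl on an amide-type nitrogen. Among the compounds with values here, no pair of measured compounds shows exactly this change on its own, so the step has to be judged from what is at hand. Compound 1 carries an aryl group on the same amide-type nitrogen, though it differs from compound 4 elsewhere too. In this assay compound 1 gives 15000 nM, which sits well below the number of compound 3. On that basis the step from compound 3 to compound 4 in this assay is expected to be downward and beyond the scatter, a 3.7-fold lower number from compound 3 to compound 4 (0.57 log units; beyond the scatter). For compound 4 the estimate in this assay is 25000 nM, with a range of 8000 nM to 70000 nM.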

Compound 4, solubility: 31500 nM
Compound 4: the middle estimate sits 1.3-fold (0.10 log units) below what was measured; the range from low to high includes it.
By their numbers in this assay, from the lowest: compounds 1, 2 and 4 (each within the scatter of the next, the first and the last beyond it); then compound 3.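

In this assay, within the data shown here, the exchange of 3,5-dimethylbenzyl for 4-fluoro-3,5-dimethylphenyl on the amide-type nitrogen gives a 2.9-fold lower number from compound 3 to compound 4 (0.47 log units; beyond the scatter) with the rest of the structure held constant, the first step that can be read at a single place. This position therefore responds to the substituent on the amide-type nitrogen, although the step is modest. No evidence at hand bears on the reason for this shift.

The step combines the replacement of benzyl by phenyl with the entry of fluorine, and the compounds shown do not separate these two changes. Going by these compounds, how an amine or a carboxylic acid carried on the amide-type nitrogen would read on the shared core also remains open.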